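This account rests on a few compounds, and the source may have more. Where it says the series, first, only, none or still open, it means among the compounds named here.

Measured in a functional assay on PC-3 cells (Homo sapiens) for antiproliferative activity, read by MTT assay, with a stated time of 48 h; on this read-out higher numbers stand for weaker inhibition and lower numbers for stronger inhibition:

- compound 1 `CCn1c(C(=O)NCCN)ccc1C(CC)(CC)c1ccc(OCCC(O)(CC)CC)c(C)c1`: 2420 nM
- compound 2 `CCn1c(C(=O)N(CCC#N)CCC#N)ccc1C(CC)(CC)c1ccc(OCCC(O)(CC)CC)c(C)c1`: > 50000 nM (a limit)
- compound 3 `CCOc1ccc(NC(=O)c2ccc(C(CC)(CC)c3ccc(OCCC(O)(CC)CC)c(C)c3)n2CC)cc1`: > 50000 nM (a limit)

Compound 3 has no exact number, only the limit > 50000 nM. This is the limit of > 50000 nM in this assay, at which 2 of the 3 values shown sit. Compound 4 `CCn1c(C(=O)NC(C)C(=O)O)ccc1C(CC)(CC)c1ccc(OCCC(O)(CC)CC)c(C)c1` carries 1-carboxyethyl in place of 4-ethoxyphenyl on an amide-type nitrogen.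

Two large steps bear on this change. Putting 4-ethoxyphenyl in place of 2-aminoethyl gave an at least 20-fold higher number from compound 1 to compound 3 (1.31 log units; beyond the scatter), and a different swap on the carbonyl carbon gave an at least 20-fold higher number from compound 1 to compound 2 (1.31 log units; beyond the scatter). Compound 1 alone gives a real number, 2420 nM, so the group on the amide matters greatly in this assay. Like compound 1, compound 4 has no ring in that group. Compound 2 also has none, however, and it goes against any simple pattern, with its limit of > 50000 nM.

A modest fall in the number is therefore expected, and the estimated change is an at least 2.5-fold lower number from compound 3 to compound 4 (0.39 log units; beyond the scatter). The estimate for compound 4 is 20000 nM, with an expected range of 4000 nM to 50000 nM.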

Compound 4, half-maximal inhibitory concentration: 11700 nM
Compound 4: the middle estimate sits 1.7-fold (0.23 log units) above what was measured; the measured number falls inside the stated range.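

Putting 1-carboxyethyl in place of 4-ethoxyphenyl on the amide-type nitrogen gives an at least 4.2-fold lower number from compound 3 to compound 4 (0.63 log units; beyond the scatter) in this assay, and replacing the whole group on the carbonyl carbon gives an at least 4.2-fold lower number from compound 2 to compound 4 (0.63 log units; beyond the scatter). A second ring-free chain on this nitrogen therefore gives an exact number, yet the two chains do not behave alike, with 1-carboxyethyl in place of 2-aminoethyl giving a 4.8-fold higher number from compound 1 to compound 4 (0.68 log units; beyond the scatter). The two drops are only minimum sizes, since each starts from a limit, and compound 2, which has no ring in this group, goes against any rule that ring-free groups keep activity: the limit of > 50000 nM in this assay, at which 2 of the 4 values shown sit.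

From the compounds shown here alone, it remains open whether the carboxylic acid itself matters or only the short chain carrying it, which a plain ethyl group or a methyl ester could separate. Going by these compounds, how a longer chain ending in an amine would compare with compound 1 is also open.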